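Neopentyl to benzyl: expected clearance of compound 3

A few compounds are considered here, and "the series" means these few. Any claim that something is new, unique, unknown or untested is made for them only; others in the source may bear on it.

For the measured compounds named here, in an ADME assay on liver for metabolic stability, with Liver microsome (Homo sapiens) as the target, read by LC-MS, using microsomes (on this read-out higher numbers stand for fast clearance and lower numbers for slow clearance), compound 2 `CC(C)(C)C[C@@H](O)C(=O)N1N=CC[C@H]1C(=O)NCc1cc(Cl)ccc1-n1cnnn1` gives 22 mL.min-1.g-1 as the only actual number so far. Compound 1 `CC1(C[C@@H](O)C(=O)N2N=CC[C@H]2C(=O)NCc2cc(Cl)ccc2-n2cnnn2)CC1` stands at < 12 mL.min-1.g-1 which is a limit of the assay. The change to compound 3 `O=C(NCc1cc(Cl)ccc1-n1cnnn1)[C@@H]1CC=NN1C(=O)[C@H](O)Cc1ccccc1` is phenyl in place of tert-butyl on a saturated chain carbon, two bonds along the chain from a carbonyl carbon and an oxygen on a saturated carbon with phenyl in place of tert-butyl on a saturated chain carbon. Going by the values given here, the one measured step at this place is an at least 1.8-fold higher number from compound 1 to compound 2 (0.26 log units; that floor lies within the scatter) and it involves a different pair of groups, so it sets no size for this change. In this assay no step beyond the scatter is expected, and the estimated step is a 1.1-fold higher number from compound 2 to compound 3 (0.06 log units; within the scatter) overall. Compound 3 is expected at 25 mL.min-1.g-1 with an estimated range from 12 mL.min-1.g-1 to 50 mL.min-1.g-1 on this read-out.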

Compound 3, intrinsic clearance in microsomes: < 12 mL.min-1.g-1
Compound 3: a limit, no number; the forecaster's own chance of this, stated with the estimate: 15%; middle value at least 2.0-fold (0.31 log units) away from the limit.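

In this assay, phenyl in place of tert-butyl at this position gives an at least 1.8-fold lower number from compound 2 to compound 3 (0.26 log units; that floor lies within the scatter), and this is a floor rather than a size. The values of compound 1 and compound 3 are both limits, so the step between them cannot be read. Differences among these groups cannot be sized further, because the read-out stops here: the limit of < 12 mL.min-1.g-1 in this assay, at which 2 of the 3 values shown sit.

As far as these compounds go, how far compound 1 and compound 3 actually lie from that limit remains open. So does whether a pyridyl or cyclohexyl group on the same chain carbon would also reach it.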